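Hydrazone series: thiourea in place of the cyanoacetyl group

The compounds below may be only part of what the source reports. "The series", "measured", "known", "first", "only" and "open" are said of these compounds alone.

Measured so far in a functional assay, tested at 2 mM; on this read-out higher numbers stand for more inhibition at the one concentration tested (going by the name of the read-out) and lower numbers for less inhibition:
compound 1 `C/C(=N\NC(=O)/C(C#N)=C\c1ccc(F)cc1)c1nc(-c2ccccc2)[nH]c1C` gives 68.6%
compound 2 `C/C(=N\NC(=O)CC#N)c1nc(-c2ccccc2)[nH]c1C` gives 48.2%
compound 3 `C/C(=N\N=C1\N=C(c2ccccc2)CS1)c1nc(-c2ccccc2)[nH]c1C` gives 79.4%

Of the three numbers in this assay, compound 2 stands lowest. Compound 1 lies nearest, with a reading higher by an amount that is beyond the scatter; compound 3 lies furthest, again higher by an amount beyond the scatter. For the measured compounds named here, no pair of these three differs in only one place, so no single step among the measured compounds can be read off.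

Compound 4 `C/C(=N\NC(N)=S)c1nc(-c2ccccc2)[nH]c1C` has not yet been measured in this assay. It comes from compound 2 by the change a group of 3 heavy atoms (1 carbon, 1 nitrogen, 1 sulfur; no ring) in place of a group of 5 heavy atoms (3 carbon, 1 nitrogen, 1 oxygen; no ring), on an amine nitrogen: the (cyanomethyl)carbonyl group leaves and the smaller group without a common name enters, on the amine nitrogen whose other neighbour is the double-bonded nitrogen.

With no measured step of this kind in the series, the expected change is a small rise, likely within the scatter; the step of a number 6.8 percentage points higher from compound 2 to compound 4 (within the scatter) is the estimate. Compound 4 is expected to give 55% in this assay, within 35% to 75%.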

Compound 4, a percentage reported as inhibition, at one concentration (the size of the read-out at that concentration, not a potency): 60.2%
Estimate against measurement, compound 4: 5.2 percentage points below, within the range that was stated.
By their numbers in this assay, from the lowest: compound 2; then compounds 4 and 1 (each within the scatter of the next); then compound 3.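

In this assay this amine nitrogen, whose other neighbour is the double-bonded nitrogen, now has its first single-change reading: the group of 3 heavy atoms in place of (cyanomethyl)carbonyl gives a number 12 percentage points higher from compound 2 to compound 4 (beyond the scatter) as a modest step. The carbonyl and nitrile of the leaving group are therefore not needed to hold the reading at this one concentration, and the smaller thiourea group serves at least as well here. Nothing at hand accounts for the size or direction of this step.

On these data alone, whether the sulfur or the free amine of the thiourea carries the step stays open, and the matching urea, with oxygen in place of sulfur, or a thiourea with a methyl group on that amine would separate the two. A plain acetyl group at the same place would show what the nitrile contributes to compound 2.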